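This account rests on a few compounds, and the source may have more. Where it says the series, first, only, none or still open, it means among the compounds named here.

Three compounds share a core in which a pyridine carries an amidine-like arm linked to a thiourea. Compound 1 `Cc1cccc(/C(N)=N/NC(=S)N2CCCCC2)n1` and compound 2 `Cc1cccc(/C(N)=N/NC(=S)N2CCCC2)n1` differ only in the ring on the thiocarbonyl carbon; compound 3 `Cc1ccnc(/C(N)=N/NC(=S)N2CCN(c3ccccn3)CC2)c1` carries a methyl on its pyridine and a larger ring on the thiocarbonyl carbon.

In a functional assay on A-375 cells (Homo sapiens) for cytotoxicity, read by MTT assay, with a stated time of 72 h, tested at 100 uM (a lower number here means less inhibition of growth, a higher number more inhibition of growth at the concentration tested), compound 1 gives 85.7%, compound 2 gives 66.3% and compound 3 gives 81%. Among the compounds with values here, the single measured step, a number 19.4 percentage points lower from compound 1 to compound 2 (beyond the scatter), concerns the ring on the thiocarbonyl carbon. Compound 3 stands second highest of the three numbers: its number and that of compound 1 lie within the scatter of each other, while its number lies beyond the scatter above that of compound 2.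

Compound 4 `N/C(=N\NC(=S)N1CCN(c2ccccn2)CC1)c1ccccn1` differs from compound 3 by hydrogen in place of methyl on an aromatic carbon. Within the data shown here, no measured step touches that methyl, so the one measured step gives no guidance here.

For compound 4 the number is expected to stay close, with a step of a number 4 percentage points lower from compound 3 to compound 4 (within the scatter), so an estimate of 77%, between 60% and 92%, is expected.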

Compound 4, percent growth inhibition at one concentration: 86.8%
Beside the measured number, compound 4's estimate is 9.8 percentage points below it, within the range that was stated.
By their numbers in this assay, from the lowest: compound 2; then compounds 3, 1 and 4 (each within the scatter of the next).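

In this assay, within the data shown here, the swap of 4-methylpyridin-2-yl for pyridin-2-yl gives a number 5.8 percentage points higher from compound 3 to compound 4 (within the scatter), and this is the first measured look at this position. At this aromatic carbon, opposite the ring nitrogen, hydrogen and methyl therefore cannot be told apart in this read-out at the single concentration tested. Nothing available here bears on what lies behind this result.

From the compounds shown here alone, whether the position stays this undemanding with a different group, such as a methoxy group, an amine or a longer chain like ethyl, remains open. Also open, going by these compounds, is whether the methyl can be removed with the same result when the ring on the thiocarbonyl carbon is piperidin-1-yl or pyrrolidin-1-yl rather than the larger ring carried by these two compounds.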